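Compound 3: pyrimidin-5-yl in place of 3-cyanophenyl

The compounds below may be only part of what the source reports. "The series", "measured", "known", "first", "only" and "open" are said of these compounds alone.

Measured in a physicochemical assay for solubility, at pH 2 (on this read-out higher numbers stand for higher solubility and lower numbers for lower solubility), so far:
- compound 1 `CNc1nc(NCCCN(C)C)c2sc(-c3ccc(NS(C)(=O)=O)cc3)cc2n1` gives > 100 ug/mL as a limit
- compound 2 `CNc1nc(NCCCN(C)C)c2sc(-c3cccc(C#N)c3)cc2n1` gives > 100 ug/mL as a limit

Compound 2 sits at the limit of > 100 ug/mL in this assay, at which 2 of the 2 values shown sit, and that is a limit, not a number. Compound 3 `CNc1nc(NCCCN(C)C)c2sc(-c3cncnc3)cc2n1` carries pyrimidin-5-yl in place of 3-cyanophenyl on an aromatic carbon. Among the measured compounds shown here, no measured step covers this change. In this assay the expected step, a step that the limit leaves unreadable from compound 2 to compound 3, is none beyond the scatter, in either direction. The estimate for compound 3 is 150 ug/mL, with an expected range of 70 ug/mL to 300 ug/mL, and a limit alone is the likeliest report.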

Compound 3, solubility: 214 ug/mL
Compound 3: middle estimate off by 1.4-fold (0.15 log units), on the low side; low and high end bracket the measured number.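

Among the compounds shown here, no step from compound 2 to compound 3 can be read, because compound 2 gives a limit and not a number: the limit of > 100 ug/mL in this assay, at which 2 of the 3 values shown sit. As far as these compounds go, the size and direction of any difference between 3-cyanophenyl and pyrimidin-5-yl remain open.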